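A few compounds are considered here, and "the series" means these few. Any claim that something is new, unique, unknown or untested is made for them only; others in the source may bear on it.

Working notes on the series built on the core of compound 1 (`CC1=CC[C@H]2[C@@H]1CC=C(C)[C@@H](CC[C@H]1[C@]3(C)CC[C@H](OC(=O)c4ccccc4)C(C)(C)O[C@H]3CC[C@@]1(C)O)C2(C)C`). In a functional assay on MDA-MB-231 cells (Homo sapiens) for antiproliferative activity, read by MTT assay, with a stated time of 72 h (on this read-out higher numbers stand for weaker inhibition and lower numbers for stronger inhibition), compound 1 gives 18400 nM as its value, and compound 2 (`CC1=CC[C@H]2[C@@H]1CC=C(C)[C@@H](CC[C@H]1[C@]3(C)CC[C@H](OC(=O)c4ccc(C)cc4)C(C)(C)O[C@H]3CC[C@@]1(C)O)C2(C)C`) gives 32700 nM as its value. These two numbers lie within the scatter of each other, so compound 2 cannot be separated from compound 1.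

Compound 3 (`CC1=CC[C@H]2[C@@H]1CC=C(C)[C@@H](CC[C@H]1[C@]3(C)CC[C@H](OC(=O)c4ccc(Cl)cc4)C(C)(C)O[C@H]3CC[C@@]1(C)O)C2(C)C`) carries chloro in place of methyl on an aromatic carbon, para to a large group (chloro in place of methyl on an aromatic carbon). Among the compounds with values here, the only measured step bearing on this is a 1.8-fold higher number from compound 1 to compound 2 (0.25 log units; within the scatter) for methyl in place of hydrogen on an aromatic carbon, and it stays within the scatter. Within the data shown here, no measured compound carries chloro, so this support is indirect. No step beyond the scatter is therefore expected in this assay, and no direction is favoured.

The expected change is a 1.3-fold lower number from compound 2 to compound 3 (0.12 log units; within the scatter) in this estimate, which lies within the scatter. For compound 3 the estimated value is 25000 nM as the middle, with an expected range from 12000 nM to 50000 nM for now.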

Compound 3, half-maximal inhibitory concentration: 12700 nM
Estimate against measurement, compound 3: 2.0-fold (0.29 log units) above, and the stated range covers the measured number.
By their numbers in this assay, from the lowest: compounds 3, 1 and 2 (each within the scatter of the next, the first and the last beyond it).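

Chloro in place of methyl on this aromatic carbon, para to a large group, gives a 2.6-fold lower number from compound 2 to compound 3 (0.41 log units; beyond the scatter) in this assay, a modest step and the first in the series to lie beyond the scatter, so the group carried here can separate two compounds. That separation does not extend to hydrogen: chloro in its place gives a 1.4-fold lower number from compound 1 to compound 3 (0.16 log units; within the scatter) in this assay, and compound 3 cannot be told apart from compound 1. Nothing available accounts for the step between methyl and chloro.

The compounds shown leave open how an amine, a carboxylic acid or a nitrile on the same aromatic carbon would compare with methyl and chloro. They also leave open whether an amide in place of the ester link would keep these differences.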